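Dichlorophenyl for difluorophenyl on a saturated ring carbon

The compounds below may be only part of what the source reports. "The series", "measured", "known", "first", "only" and "open" are said of these compounds alone.

For the measured compounds named here, in an assay on cells for inhibition of histone deacetylase 4 (Homo sapiens), read by fluorescence, with a stated time of 30 min (on this read-out higher numbers stand for weaker inhibition and lower numbers for stronger inhibition), compound 2 `O=C1NC(=O)/C(=C\c2ccc(OCC(=O)N3N=C(c4ccccc4)CC3c3ccc(F)cc3F)cc2)S1` gives 2200 nM, one of only two numbers measured so far. Compound 1 `O=C1NC(=O)/C(=C\c2ccc(OCC(=O)N3N=C(c4ccccc4)CC3c3ccccc3)cc2)S1` gives 1600 nM in the same assay, and the step of a 1.4-fold higher number from compound 1 to compound 2 (0.14 log units; within the scatter) lies within the scatter. Compound 3 `O=C1NC(=O)/C(=C\c2ccc(OCC(=O)N3N=C(c4ccccc4)CC3c3ccc(Cl)c(Cl)c3)cc2)S1` carries 3,4-dichlorophenyl in place of 2,4-difluorophenyl on a saturated ring carbon. Going by the values given here, the one step that bears on this, a 1.4-fold higher number from compound 1 to compound 2 (0.14 log units; within the scatter), also exchanged the aryl group on that saturated ring carbon and stayed within the scatter, so for compound 3 the expected step is a 1.1-fold lower number from compound 2 to compound 3 (0.04 log units; within the scatter), with no change beyond the scatter. Compound 3 is therefore estimated at 2000 nM, between 800 nM and 5000 nM.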

Compound 3, half-maximal inhibitory concentration: 700 nM
For compound 3 the middle estimate is 2.9-fold (0.46 log units) above the measured one; the measured number lies below the stated range.
By their numbers in this assay, from the lowest: compound 3; then compounds 1 and 2 (each within the scatter of the next).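

In this assay the saturated ring carbon next to the ring nitrogen proves responsive to its aryl group: 3,4-dichlorophenyl gives a 3.1-fold lower number from compound 2 to compound 3 (0.50 log units; beyond the scatter) and also a 2.3-fold lower number from compound 1 to compound 3 (0.36 log units; beyond the scatter) on the same shared core. For the compounds shown here, the earlier exchange at this carbon had stayed within the scatter, so this is the first change here that clearly moves the number, and compound 3 stands lowest of the three. The entering and leaving groups have the same heavy-atom count, yet the number still shifts.

No measured evidence accounts for this shift. The compounds shown leave open whether the chlorine atoms or their placement carry the step, and how a 4-chlorophenyl, a 4-methoxyphenyl or a pyridine ring would read at this carbon.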